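Chain lengthening on two cores, paw edema readout

This account rests on a few compounds, and the source may have more. Where it says the series, first, only, none or still open, it means among the compounds named here.

Measured so far:
compound 1 `CCCn1c(Cn2c(=O)oc3ccc(C)cc32)n[nH]c1=S` — 160%
compound 2 `CCn1c(Cn2c(=O)oc3ccc(C)cc32)n[nH]c1=S` — 147%
compound 3 `CCNc1nnc(Cn2c(=O)oc3ccc(C)cc32)s1` — 94%

All three were run in a functional assay on the whole organism with Mus musculus as the target, read by paw edema, with a stated time of 360 min, at a dose of 50 mg/kg by the oral route; on this read-out lower numbers stand for a stronger effect and higher numbers for a weaker effect at the one dose given. Compound 3 stands lowest of the three; compound 2 and compound 1 lie well above it, both steps beyond the scatter. The difference between the core of compound 3 and the core of compound 2 is not broken down here.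

Within the core of compound 2, the change methyl in place of hydrogen on a saturated chain carbon, two bonds along the chain from an aromatic nitrogen gave a number 13 percentage points higher from compound 2 to compound 1 (beyond the scatter).

Compound 4 `CCCNc1nnc(Cn2c(=O)oc3ccc(C)cc32)s1` carries the same kind of change on the core of compound 3: methyl in place of hydrogen on a saturated chain carbon, two bonds along the chain from a nitrogen on an aromatic ring. The place differs in wording only: in compound 1 the carbon sits two bonds from an aromatic nitrogen, in compound 4 two bonds from a nitrogen on an aromatic ring. With one measured instance of this kind of change, the expectation for compound 4 rests on that single step alone, and for compound 4 a step of a number 13 percentage points higher from compound 3 to compound 4 (beyond the scatter) is expected in this assay. Compound 4 is accordingly estimated at 107%, with a range from 85% to 130%.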

Compound 4, a percentage reported as activity, at one dose (the size of the read-out at that dose, not a potency): 110%
Compound 4: the middle estimate sits 3 percentage points below what was measured; the measured number falls inside the stated range.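

In this assay, going from ethylamino to propylamino gives a number 16 percentage points higher from compound 3 to compound 4 (beyond the scatter), a move toward a weaker effect at the one dose given. Set beside the ethyl to propyl step on the other core, the change carries over in both direction and size: the same change on two cores in this assay, a number 13 percentage points higher (beyond the scatter) from compound 2 to compound 1 and a number 16 percentage points higher (beyond the scatter) from compound 3 to compound 4, 3 percentage points apart, within the scatter of two such steps

Among these compounds, this agreement rests on only two pairs and two cores, at a single dose and time, so it supports carrying this one change between these two cores but does not show that it would hold on a further core or explain why the number rises.

Still open, on these data alone, is whether a longer chain such as butyl, a branched chain such as isopropyl, or a chain carrying a hydroxyl group or an amine would continue the same rise on either core. Also open, as far as these compounds go, is whether any such group would improve on compound 3, at 94%.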